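The source may hold more compounds than are shown below. What is called first, only, known or untested is meant among the compounds shown, and "the series" means these compounds.

Among the compounds with values here, in a functional assay on MV4-11 cells (Homo sapiens) for antiproliferative activity, read by luminescence and CellTiter-Glo, with a stated time of 72 h (on this read-out lower numbers stand for stronger inhibition and higher numbers for weaker inhibition), three compounds built on a shared core have numbers so far. Compound 1 (`CNc1cc(-c2ccc3cnn(Cc4ccc(F)cc4)c3c2)cn(C)c1=O`) gives 2390 nM, compound 2 (`CNc1cc(-c2ccc3cnn(Cc4cc(OC)cc(OC)c4)c3c2)cn(C)c1=O`) gives 190 nM, and compound 3 (`CCNc1cc(-c2ccc3cnn(Cc4ccc(F)cc4)c3c2)cn(C)c1=O`) gives 5650 nM. Compound 3 therefore holds the highest of the three numbers, and its gaps to both others lie beyond the scatter.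

Compound 4 (`CCNc1cc(-c2ccc3cnn(Cc4cc(OC)cc(OC)c4)c3c2)cn(C)c1=O`) has not been measured and differs from compound 3 in one place: 3,5-dimethoxyphenyl in place of 4-fluorophenyl on a saturated chain carbon bound to an aromatic nitrogen.

Within the data shown here, two measured steps bear on this change. The same exchange has been seen once already, and it was large: a 13-fold lower number from compound 1 to compound 2 (1.10 log units; beyond the scatter). The second step, which is modest, is a 2.4-fold higher number from compound 1 to compound 3 (0.37 log units; beyond the scatter). It separates compound 3 from compound 1, and the same change separates compound 4 from compound 2. If the two changes add up independently, the exchange should keep about its full size when made on compound 3. That assumption rests on a single pair, so the size remains uncertain, although the direction is better supported.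

The expected result is a large move towards stronger inhibition, a 13-fold lower number from compound 3 to compound 4 (1.10 log units; beyond the scatter). Compound 4 is estimated at 450 nM, with an expected range from 180 nM to 1100 nM.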

Compound 4, half-maximal inhibitory concentration: 2590 nM
For compound 4 the middle estimate is 5.8-fold (0.76 log units) below the measured one; measured number above the stated range.
By their numbers in this assay, from the lowest: compound 2; then compounds 1 and 4 (each within the scatter of the next); then compound 3.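

In this assay, the exchange of 4-fluorophenyl for 3,5-dimethoxyphenyl keeps its direction when the extra methyl is present, but its size falls to a 2.2-fold lower number from compound 3 to compound 4 (0.34 log units; beyond the scatter), so the gain depends on the rest of the molecule: the same change on two cores in this assay, a 13-fold lower number (1.10 log units; beyond the scatter) from compound 1 to compound 2 and a 2.2-fold lower number (0.34 log units; beyond the scatter) from compound 3 to compound 4, 5.8-fold (0.76 log units) apart, beyond the scatter of two such steps

Seen from the other side, adding that methyl on the saturated chain carbon bound to a nitrogen on an aromatic ring has a much larger effect with 3,5-dimethoxyphenyl in place, a 14-fold higher number from compound 2 to compound 4 (1.13 log units; beyond the scatter), than it has with 4-fluorophenyl: the same change on two cores in this assay, a 2.4-fold higher number (0.37 log units; beyond the scatter) from compound 1 to compound 3 and a 14-fold higher number (1.13 log units; beyond the scatter) from compound 2 to compound 4, 5.8-fold (0.76 log units) apart, beyond the scatter of two such steps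

Across these four compounds the two changes therefore do not add up independently, and the lowest number appears only in compound 2, which has 3,5-dimethoxyphenyl without the extra methyl.

The compounds shown do not tell whether a longer chain, such as propyl, would raise the number further when 3,5-dimethoxyphenyl is present. They also leave open whether a phenyl ring with a single methoxy group would give the same dependence on the extra methyl, and they give no explanation for that dependence.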